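A few compounds are considered here, and "the series" means these few. Any claim that something is new, unique, unknown or untested is made for them only; others in the source may bear on it.

Three compounds of one shared core have been characterised in a toxicity assay on the whole organism (strain Icem-CET (SPF Caw)) for cytotoxicity, with Mus musculus as the target; a lower number here means that less compound is needed, a higher number that more compound is needed for the effect. Compound 1, with the structure `C=CCNC(=O)/C(C)=C(/C)c1ccc(Cl)cc1`, gives 400 mg/kg in this assay. Compound 2, with the structure `C#CCNC(=O)/C(C)=C(\C)c1ccccc1`, gives 150 mg/kg in this assay, and compound 3, with the structure `C#CCNC(=O)/C(C)=C(\C)c1ccc(C)cc1`, gives 150 mg/kg in this assay. Going by the values given here, the single step measured between two of these, methyl in place of hydrogen on an aromatic carbon, is no change at the digits printed from compound 2 to compound 3 (within the scatter). Among the three numbers compound 1 stands highest, its values against compound 2 and against compound 3 both lying beyond the usual scatter, so that compound 1 needs more compound for the effect than either of the other two.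

The next compound, compound 4, has the structure `C=CCNC(=O)/C(C)=C(/C)c1ccc(OC)cc1`. It differs from compound 1 in one place: methoxy in place of chloro on an aromatic carbon. Among the compounds with values here, the only measured step that speaks to a change at an aromatic carbon of this ring is the one from compound 2 to compound 3, and that step is within the scatter. On this basis a step of little size is expected in this assay from compound 1 to compound 4, with no direction beyond the scatter, namely no change at the digits printed from compound 1 to compound 4 (within the scatter). Compound 4 is therefore estimated to give 400 mg/kg in this assay, expected to fall between 200 mg/kg and 800 mg/kg.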

Compound 4, dose for half-maximal effect: 400 mg/kg
The estimate for compound 4 equals the measured number at the digits printed; low and high end bracket the measured number.
By their numbers in this assay, from the lowest: compounds 2 and 3 (each within the scatter of the next); then compounds 1 and 4 (each within the scatter of the next).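

On an aromatic carbon para to a large group, methoxy in place of chloro gives no change at the digits printed from compound 1 to compound 4 (within the scatter) in this assay, so two different substituents at this position, one of them bringing a hydrogen-bond acceptor and a second heavy atom, give the same reading on the core of compound 1. The earlier step, no change at the digits printed from compound 2 to compound 3 (within the scatter), showed only that methyl could replace hydrogen at this position in a pair with a different amide substituent, whereas this result concerns the exchange of one substituent for another in the pair that carries the double-bond-containing amide substituent of compound 1. Nothing available bears on why the reading stays the same across this exchange.

The compounds shown leave open whether an amine, a carboxylic acid or a longer alkoxy chain at this position would also stay within the scatter of compound 1, or would move the number in either direction. They also leave open whether methoxy in place of hydrogen on compound 2 would give the same kind of result as the methyl of compound 3.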